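Allyloxy to pyridin-2-yl on the compound 1 core: clearance outlook

This account rests on a few compounds, and the source may have more. Where it says the series, first, only, none or still open, it means among the compounds named here.

The series is followed in an ADME assay on microsomes from liver (Homo sapiens) for metabolic stability, read by HPLC, using NADPH, with a stated time of 60 min, tested at 1 uM, in the presence of a further agent that is not named here; a higher number here means faster removal of the compound, a lower number slower removal. Within the data shown here, compound 1 `C=CCOc1cc(F)cc(C(=O)NNS(=O)(=O)c2ccccc2F)c1` is the higher of the two numbers so far: in this assay compound 1 gives 138 uL/min. The nearest neighbour is compound 2 `C=CCOc1cc(C)c(F)c(C(=O)NNS(=O)(=O)c2ccccc2)c1`, which in this assay gives 73 uL/min; the two values lie within the usual scatter of the method, so no order between them is claimed.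

Compound 3 `O=C(NNS(=O)(=O)c1ccccc1F)c1cc(F)cc(-c2ccccn2)c1` is the next member and has not yet been run in this assay. Relative to compound 1 the change is pyridin-2-yl in place of allyloxy on an aromatic carbon. Among the measured compounds shown here, no step between measured compounds isolates a change of this kind, so the expectation rests only on the two numbers in hand and on the size of the change itself.

The step from compound 1 to compound 3 is expected to be a 1.7-fold lower number from compound 1 to compound 3 (0.24 log units; within the scatter), a modest move toward slower removal that may not clear the scatter. For compound 3 the estimate in this assay is 80 uL/min, with a range from 35 uL/min to 180 uL/min.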

Compound 3, intrinsic clearance in a liver preparation (reported as CLH), per the amount of preparation that the assay uses: 31 uL/min
Compound 3: the middle estimate sits 2.6-fold (0.41 log units) above what was measured; the whole stated range lies above it.
By their numbers in this assay, from the lowest: compound 3; then compounds 2 and 1 (each within the scatter of the next).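

The aromatic carbon that carries allyloxy is now shown to matter for removal in this assay: pyridin-2-yl in place of allyloxy gives a 4.5-fold lower number from compound 1 to compound 3 (0.65 log units; beyond the scatter), the first step in the series between compounds that differ in one place, and it lies beyond the scatter. The step comes with a ring entering and the double bond outside aromatic rings leaving, while the counts of hydrogen-bond donors and acceptors and the net charge stay the same, so a change at this one place can move the read-out without any change in those counts. No measurement in hand bears on the reason for the step.

A single pair cannot separate the loss of allyloxy from the arrival of pyridin-2-yl; a saturated propoxy chain or a phenyl group on the same aromatic carbon of the core of compound 1 would begin to divide the two. Going by these compounds, it also remains open whether the same exchange gives a step of similar size on the core of compound 2, which carries allyloxy as well.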